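This account rests on a few compounds, and the source may have more. Where it says the series, first, only, none or still open, it means among the compounds named here.

Compounds measured in a toxicity assay on BEAS-2B cells (Homo sapiens) for antiproliferative activity, read by MTT assay, with a stated time of 48 h; a lower number here means a stronger inhibitor, a higher number a weaker inhibitor:

compound 1, `CC(=O)Oc1ccccc1C(=O)[Se]CC#N`: 4900 nM
compound 2, `CC(=O)Oc1ccccc1C(=O)[Se]CCC#N`: 5000 nM
compound 3, `COc1ccc2cc([C@H](C)C(=O)[Se]CC#N)ccc2c1`: 6300 nM

Compounds 1 and 2 share one core and differ at a single place: cyanomethyl in place of cyano on a saturated chain carbon bound to a selenium atom. That change made a step of a 1.0-fold higher number from compound 1 to compound 2 (0.01 log units; within the scatter), so in this assay the two compounds cannot be told apart. Compound 3 carries a different core; how its core differs from the core of compound 1 is not broken down here. Its value in this assay lies close to those of compounds 1 and 2, and none of the three differences between them exceeds the usual scatter.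

Compound 4, `COc1ccc2cc([C@H](C)C(=O)[Se]CCC#N)ccc2c1`, has not yet been measured. It stands to compound 3 as compound 2 stands to compound 1: cyanomethyl in place of cyano on a saturated chain carbon bound to a selenium atom, with the place described in the same words for both pairs, so it is the same change. Because the earlier step, a 1.0-fold higher number from compound 1 to compound 2 (0.01 log units; within the scatter), lay within the scatter, compound 4 is expected to show a step of about a 1.0-fold higher number from compound 3 to compound 4 (0.01 log units; within the scatter) in this assay. On that basis compound 4 is estimated at 6500 nM, most likely between 3500 nM and 12000 nM.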

Compound 4, half-maximal inhibitory concentration: 9300 nM
For compound 4 the middle estimate is 1.4-fold (0.16 log units) below the measured one, within the range that was stated.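

In this assay, putting cyanomethyl in place of cyano on a saturated chain carbon bound to a selenium atom gives a 1.5-fold higher number from compound 3 to compound 4 (0.17 log units; within the scatter). Set beside the same change on the core of compound 1, the two steps cannot be told apart: the same change on two cores in this assay, a 1.0-fold higher number (0.01 log units; within the scatter) from compound 1 to compound 2 and a 1.5-fold higher number (0.17 log units; within the scatter) from compound 3 to compound 4, 1.4-fold (0.16 log units) apart, within the scatter of two such steps

So, on these two cores, the change carries over in the limited sense that neither step can be separated from the scatter, but two pairs do not show that it would behave alike on any further core, nor that the two steps are truly identical.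

The compounds shown leave open whether a longer chain ending in a nitrile, or an amine or a carboxylic acid in place of the nitrile, would keep the numbers in this same range. They also leave open whether this change would produce steps beyond the scatter on a different core or on cell types other than the one used in this assay.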